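From a 4-hydroxyphenyl to a 2,6-dimethoxyphenyl group

The source may report more compounds than this note shows. Statements on the series, on what has been measured and on what is new or still open speak of the compounds shown alone.

In a functional assay on CAKI-1 cells (Homo sapiens) for inhibition, read by sulforhodamine B assay, with a stated time of 48 h (on this read-out higher numbers stand for weaker inhibition of growth and lower numbers for stronger inhibition of growth), compound 1 (`O=C(Cc1csc2nc(-c3ccc(Br)cc3)cn12)N/N=C/c1ccccc1`) gives 81300 nM and compound 3 (`O=C(Cc1csc2nc(-c3ccc(Br)cc3)cn12)N/N=C/c1ccc(O)cc1`) gives 49000 nM, two values within the scatter of each other. Compound 2 (`O=C(Cc1csc2nc(-c3ccc(Br)cc3)cn12)N/N=C/c1ccccc1O`) stands well apart from both at 2400 nM. Compound 4 (`COc1cccc(OC)c1/C=N/NC(=O)Cc1csc2nc(-c3ccc(Br)cc3)cn12`) carries 2,6-dimethoxyphenyl in place of 4-hydroxyphenyl on a carbon with a double bond to nitrogen. Hydroxy in place of hydrogen gave a 34-fold lower number from compound 1 to compound 2 (1.53 log units; beyond the scatter), yet also a 1.7-fold lower number from compound 1 to compound 3 (0.22 log units; within the scatter), while the two hydroxy isomers differ by a 20-fold higher number from compound 2 to compound 3 (1.31 log units; beyond the scatter). Compound 4 has no hydroxy group, so the large steps offer it no direct guide. No step beyond the scatter is expected, and the estimated step is a 1.6-fold lower number from compound 3 to compound 4 (0.21 log units; within the scatter). For compound 4 the estimate is 30000 nM, expected between 6000 nM and 95000 nM.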

Compound 4, concentration for total growth inhibition: 33900 nM
Compound 4: the middle estimate sits 1.1-fold (0.05 log units) below what was measured; low and high end bracket the measured number.
By their numbers in this assay, from the lowest: compound 2; then compounds 4, 3 and 1 (each within the scatter of the next, the first and the last beyond it).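

In this assay, 2,6-dimethoxyphenyl, which has 0 hydrogen-bond donors, stays within the scatter of 4-hydroxyphenyl, with a 1.4-fold lower number from compound 3 to compound 4 (0.16 log units; within the scatter). Unlike compound 3, however, compound 4 lies beyond the scatter of the plain phenyl compound, with a 2.4-fold lower number from compound 1 to compound 4 (0.38 log units; beyond the scatter). The 2-hydroxyphenyl group remains clearly better at this place, with a 14-fold higher number from compound 2 to compound 4 (1.15 log units; beyond the scatter), so the 2,6-dimethoxyphenyl group does not recover the low value of compound 2.

From the compounds shown here alone, whether a 2-methoxyphenyl or 2-aminophenyl group would retain that low value remains open. Nothing measured here accounts for these differences.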